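Indane imidazoles with a varied aromatic substituent

The source may hold more compounds than are shown below. What is called first, only, known or untested is meant among the compounds shown, and "the series" means these compounds.

Measured so far:
- compound 1 `Cc1c(OCC2=NCCN2)ccc(Cl)c1NS(C)(=O)=O`: > 10000 nM
- compound 2 `Clc1ccc2c(c1-c1ccn[nH]1)CCC2c1ncc[nH]1`: > 10000 nM
- compound 3 `Cc1n[nH]cc1-c1cccc2c1CCC2c1ncc[nH]1`: 902 nM

In a functional assay on CHO cells for agonist activity at Alpha-1B adrenergic receptor (Homo sapiens), read by FLIPR and calcium flux (a higher number here means that more compound is needed for the effect, a lower number that less compound is needed), compound 1 reaches only a limit of the assay, > 10000 nM. Compound 2 likewise gives only a limit in this assay, > 10000 nM. Among the compounds with values here, compound 3 is the one member of the set with a number, 902 nM. Compound 3 thus stands alone as the only measured point away from the limit of > 10000 nM in this assay, at which 2 of the 3 values shown sit. Within the data shown here, no step between two measured compounds can be counted here, since the three differ in more than one place.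

Compound 4 `COc1cccc2c1CCC2c1ncc[nH]1` is not yet measured. Its difference from compound 3 is methoxy in place of 3-methyl-1H-pyrazol-4-yl on an aromatic carbon. The step from compound 3 to compound 4 is expected to go toward weaker agonism, with a size beyond the usual scatter, a 3.9-fold higher number from compound 3 to compound 4 (0.59 log units; beyond the scatter); with two of three members already at the limit, a limit is a real possibility for compound 4 as well. The value of compound 4 in this assay is estimated at 3500 nM, within a range of 800 nM to 15000 nM.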

Compound 4, half-maximal effective concentration: > 10000 nM
Compound 4 was reported as a limit (the forecaster's own chance of this, stated with the estimate: 35%); middle value at least 2.8-fold (0.45 log units) from the limit.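

The pair gives the series its first step that can be counted, and it is large: in this assay, methoxy in place of 3-methyl-1H-pyrazol-4-yl on this aromatic carbon gives an at least 11-fold higher number from compound 3 to compound 4 (1.04 log units; beyond the scatter). The number for compound 3 therefore depends on the group at this position and not on the shared core alone. Compound 4 gives only a limit, so the step has no upper bound, and the series now clusters at a single reading: the limit of > 10000 nM in this assay, at which 3 of the 4 values shown sit.

On these data alone, what a phenyl group, a dimethylamino group or a pyrazole without the methyl would give at this position stays open, so it is unclear whether the ring, its hydrogen-bond donor or its methyl matters. Compound 2 differs from compound 3 in more than one place and cannot settle this.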